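Chloro to methyl with the series at its limit

The source may report more compounds than this note shows. Statements on the series, on what has been measured and on what is new or still open speak of the compounds shown alone.

Measured so far:
compound 1 `O=c1c(Cc2coc3cccc(OCC4CCCCC4)c3c2=O)coc2cc(Cl)ccc12`: > 10000 nM (a limit)
compound 2 `CC(C)COc1cccc2occ(Cc3coc4ccccc4c3=O)c(=O)c12`: > 10000 nM (a limit)

The read-out for both is a functional assay on NCI-H23 cells (Homo sapiens) for antiproliferative activity, read by XTT assay (on this read-out higher numbers stand for weaker inhibition and lower numbers for stronger inhibition), and neither compound has a number on it. Compound 1 stands at > 10000 nM, which is a limit and not a number. Compound 2 gives > 10000 nM, which is also a limit. Within the data shown here, the whole record so far is the limit of > 10000 nM in this assay, at which 2 of the 2 values shown sit, so no measured step is available and the two compounds cannot be ranked.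

Compound 3 `Cc1ccc2c(=O)c(Cc3coc4cccc(OCC5CCCCC5)c4c3=O)coc2c1` differs from compound 1 in one place: methyl in place of chloro on an aromatic carbon. This is methyl in place of chloro on an aromatic carbon, meta to a fused ring and para to a fused ring.

The expectation rests on compound 1 with its limit of > 10000 nM and no step beyond the scatter is expected in this assay, with a further limit the likeliest report. The expected change is a step that the limit leaves unreadable from compound 1 to compound 3, with no firm direction. For compound 3 the estimate is 12000 nM, with an expected range from 5000 nM to 30000 nM.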

Compound 3, half-maximal inhibitory concentration: 3220 nM
Beside the measured number, compound 3's estimate is 3.7-fold (0.57 log units) above it, outside the stated range (below it).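

In this assay, methyl in place of chloro on an aromatic carbon, meta to a fused ring and para to a fused ring, gives an at least 3.1-fold lower number from compound 1 to compound 3 (0.49 log units; beyond the scatter) and is the only change shown that moves the read-out off the limit, so this position is not silent, even for an exchange of one heavy atom with the rest of compound 1 unchanged. Compound 3, at 3220 nM in this assay, holds the only value among the compounds shown that is a number, which gives the series its first firm reference point for later comparisons. The size of the step is a minimum only, since its starting point in compound 1 is a limit and not a number: the limit of > 10000 nM in this assay, at which 2 of the 3 values shown sit.

From the compounds shown here alone, how much of the step belongs to methyl entering and how much to chloro leaving stays open, as does the outcome with a methoxy group or an amine on the same carbon. Also open, going by these compounds, is whether methyl at this position keeps its effect when the cycloalkyl ether of compound 3 gives way to a longer chain or a carboxylic acid.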